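Two thioimidate esters and an untested epimer

The compounds below may be only part of what the source reports. "The series", "measured", "known", "first", "only" and "open" are said of these compounds alone.

Measured so far:
Compound 1, `CCSC1=N[C@@H](C(=O)OC)[C@@H]2C(=O)N(c3ccccc3)C(=O)[C@H]12`, gives 91% in a functional assay for inhibition, tested at 100 uM; on this read-out higher numbers stand for more inhibition at the one concentration tested (going by the name of the read-out) and lower numbers for less inhibition.
Compound 2, `COC(=O)[C@H]1N=C(SC(C)C)[C@H]2C(=O)N(c3ccccc3)C(=O)[C@H]21`, gives 72% in this assay.

Of the two numbers, compound 2 stands lowest; its nearest neighbour is compound 1, whose value in this assay lies higher by a margin beyond the usual scatter.

Compound 3, `COC(=O)[C@@H]1N=C(SC(C)C)[C@H]2C(=O)N(c3ccccc3)C(=O)[C@H]21`, has not been measured. Compared with compound 2 the change is the two compounds have the same atoms and bonds and differ only in configuration as drawn: 1 of 3 stereo elements differ; a stereocentre at a saturated ring carbon is drawn S in compound 2 and R in compound 3.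

For the measured compounds named here, no step between measured compounds shows what such an inversion does to inhibition here, so the direction cannot be read from the data. Since a change at one stereocentre of the shared core may alter the read-out in either direction, a modest fall relative to compound 2 is expected, with wide uncertainty, as a number 12 percentage points lower from compound 2 to compound 3 (beyond the scatter). Compound 3 is therefore estimated to give 60% in this assay, expected to fall between 25% and 88%.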

Compound 3, a percentage reported as inhibition, at one concentration (the size of the read-out at that concentration, not a potency): 89%
For compound 3 the middle estimate is 29 percentage points below the measured one; the whole stated range lies below it.
By their numbers in this assay, from the lowest: compound 2; then compounds 3 and 1 (each within the scatter of the next).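

Inverting the one stereocentre at a saturated ring carbon, drawn S in compound 2 and R in compound 3, gives a number 17 percentage points higher from compound 2 to compound 3 (beyond the scatter) in this assay, so the read-out responds to the configuration at this position. The step can be assigned to that inversion alone because nothing else changes: the fact that compounds 2 and 3 differ only in the configuration as drawn. With this centre drawn R, methyl in place of hydrogen on a saturated chain carbon bound to a saturated chain carbon and a sulfur gives a number 2 percentage points lower from compound 1 to compound 3 (within the scatter), so in this configuration the added methyl makes no difference that can be read.

Still open, as far as these compounds go, is whether the same inversion would give a similar step with other chains on the sulfur, such as a longer chain. Also open, from the compounds shown here alone, is what a carboxylic acid would do in place of the methyl ester at the inverted centre.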